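Benzyl or aryl on the amide nitrogen: next step

The source may hold more compounds than are shown below. What is called first, only, known or untested is meant among the compounds shown, and "the series" means these compounds.

Measured in a functional assay on Huh-7 cells (Homo sapiens) for inhibition, read by MTT assay, with a stated time of 48 h; on this read-out lower numbers stand for stronger inhibition and higher numbers for weaker inhibition
- Compound 1 `COc1ccc(CNC(=O)/C=C/c2coc3cc(O)ccc3c2=O)cc1` gives 8430 nM
- Compound 2 `COc1ccc(NC(=O)/C=C/c2coc3cc(OC)ccc3c2=O)cc1` gives > 100000 nM (a limit)
- Compound 3 `COc1ccc(NC(=O)/C=C/c2coc3cc(O)ccc3c2=O)cc1` gives > 100000 nM (a limit)

Compound 3 sits at the limit of > 100000 nM in this assay, at which 2 of the 3 values shown sit, and so offers only a limit, not a number, as a starting point. The change to compound 4 `Cc1ccc(CNC(=O)/C=C/c2coc3cc(O)ccc3c2=O)cc1` is 4-methylbenzyl in place of 4-methoxyphenyl on an amide-type nitrogen, and compound 4 has not yet been measured. Going by the values given here, the one measured step is a step that the two limits leave unreadable from compound 2 to compound 3, which concerns a different change and gives no size to carry over. The closest guide is compound 1, which also has a benzyl-type group on the amide-type nitrogen and gives 8430 nM in this assay as a real number. On the strength of that value, a step towards stronger inhibition is expected, and the expected step is an at least 9.0-fold lower number from compound 3 to compound 4 (0.95 log units; beyond the scatter) in this assay. Among the compounds with values here, with only one such neighbour, the expectation stays wide. Compound 4 is estimated at 11000 nM, with an expected range from 3500 nM to 40000 nM in this assay.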

Compound 4, half-maximal inhibitory concentration: > 100000 nM
Compound 4: only a limit was reported; the forecaster's own chance of this, stated with the estimate: 15%; at least 9.0-fold (0.95 log units) between middle value and limit.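

In this assay, a benzyl-type group on the amide-type nitrogen is not enough by itself: methyl in place of methoxy on an aromatic carbon gives an at least 11-fold higher number from compound 1 to compound 4 (1.07 log units; beyond the scatter). Compound 4 gives > 100000 nM, which is a limit of the assay and not a number. The steps among compounds held at this limit cannot be read, so benzyl-type and aryl groups on the amide-type nitrogen cannot be ranked here: the limit of > 100000 nM in this assay, at which 3 of the 4 values shown sit.

Compound 1, at 8430 nM, remains the only compound shown with a real number, and it is open whether a hydroxy group, a chlorine atom or an amine in place of its methoxy would keep a measurable value. Also open, going by these compounds, is whether a longer chain on the amide-type nitrogen, such as 2-(4-methoxyphenyl)ethyl, would do so.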